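The source may hold more compounds than are shown below. What is called first, only, known or untested is meant among the compounds shown, and "the series" means these compounds.

Compound 1 `Cn1c(=O)c2nc(-c3cccc([N+](=O)[O-])c3)[nH]c2n(C)c1=O` and compound 2 `Cc1cccc(-c2nc3c(=O)n(C)c(=O)n(C)c3[nH]2)c1` share one core and differ in a single spot: methyl in place of nitro on an aromatic carbon. In an assay for binding affinity to adenosine receptor A1 (Bos taurus) (a higher number here means a weaker inhibitor, a lower number a stronger inhibitor), compound 1 gives 50 nM, while compound 2 gives 13 nM, so the step is a 3.8-fold lower number from compound 1 to compound 2 (0.59 log units; beyond the scatter). Compound 3 `Cn1c(=O)c2nc(-c3ccc([N+](=O)[O-])cc3N)[nH]c2n(C)c1=O` also carries an amino group; how its core differs from the core of compound 1 is not broken down here. In this assay compound 3 gives 2.5 nM, the lowest number of the three measured compounds. Compound 4 `Cc1ccc(-c2nc3c(=O)n(C)c(=O)n(C)c3[nH]2)c(N)c1` is compound 3 with methyl in place of nitro on an aromatic carbon. For the measured compounds named here, this is the same kind of change as the one from compound 1 to compound 2, not the same: there the spot lies meta to a large group, here meta to an amino group and para to a large group. With that difference around the spot, the expected step of a 2.5-fold lower number from compound 3 to compound 4 (0.40 log units; beyond the scatter) is set a little smaller than the earlier 3.8-fold lower number from compound 1 to compound 2 (0.59 log units; beyond the scatter). Compound 4 is thus expected to give about 1 nM, likely between 0.3 nM and 3.5 nM.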

Compound 4, half-maximal inhibitory concentration: 10 nM
Compound 4: the middle estimate sits 10-fold (1.00 log units) below what was measured; the whole stated range lies below it.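

Methyl in place of nitro gives a 4.0-fold higher number from compound 3 to compound 4 (0.60 log units; beyond the scatter) in this assay. On these two cores, then, the change does not carry over, not even in direction, so a step seen on one core is a poor guide to the other: the same change on two cores in this assay, a 3.8-fold lower number (0.59 log units; beyond the scatter) from compound 1 to compound 2 and a 4.0-fold higher number (0.60 log units; beyond the scatter) from compound 3 to compound 4, 15-fold (1.19 log units) apart, beyond the scatter of two such steps What this does not show is the reason: the core of compound 3 carries an amino group and the spot also sits differently there, and two pairs cannot separate these differences.

From the compounds shown here alone, it remains open whether the amino group alone would turn the step around. Also open, going by these compounds, is how another group at this spot, such as a carboxylic acid or an ethyl chain, would behave on each core.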